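Replacing 3-methylpiperazin-1-yl with cyclohexylamino on a carbonyl carbon

The source may hold more compounds than are shown below. What is called first, only, known or untested is meant among the compounds shown, and "the series" means these compounds.

Compound 1 `Nc1sc(-c2ccc(Cl)cc2)c(-c2ccc(Cl)cc2)c1C(=O)N1CCCCC1` gives 4620 nM
Compound 2 `Nc1sc(-c2ccc(Cl)cc2)c(-c2ccc(Cl)cc2)c1C(=O)N1CCCCC1=O` gives 1820 nM
Compound 3 `CC1CN(C(=O)c2c(N)sc(-c3ccc(Cl)cc3)c2-c2ccc(Cl)cc2)CCN1` gives 4930 nM

All three were tested in a functional assay on A549 cells (Homo sapiens) for inhibition, read by sulforhodamine B assay, with a stated time of 72 h; a higher number here means a weaker inhibitor, a lower number a stronger inhibitor. The data show a 1.1-fold higher number from compound 1 to compound 3 (0.03 log units; within the scatter), and also a 2.7-fold higher number from compound 2 to compound 3 (0.43 log units; beyond the scatter), so compound 3 sits level with compound 1 and apart from compound 2.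

Compound 4 `Nc1sc(-c2ccc(Cl)cc2)c(-c2ccc(Cl)cc2)c1C(=O)NC1CCCCC1` alters only the group on the carbonyl carbon: cyclohexylamino in place of 3-methylpiperazin-1-yl on a carbonyl carbon. For the measured compounds named here, no measured compound carries cyclohexylamino. The three measured changes at this place were small to modest, including a 2.5-fold lower number from compound 1 to compound 2 (0.40 log units; beyond the scatter), so no step beyond the scatter is expected in this assay. The estimated move is a 1.2-fold lower number from compound 3 to compound 4 (0.09 log units; within the scatter). For compound 4 the expected value is 4000 nM, with an estimated range of 1700 nM to 9000 nM.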

Compound 4, half-maximal inhibitory concentration: 2410 nM
Compound 4: middle estimate off by 1.7-fold (0.22 log units), on the high side; the range from low to high includes it.
By their numbers in this assay, from the lowest: compounds 2, 4, 1 and 3 (each within the scatter of the next, the first and the last beyond it).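

In this assay, cyclohexylamino gives a 2.0-fold lower number from compound 3 to compound 4 (0.31 log units; beyond the scatter), so this change of group on the carbonyl carbon moves the number by a modest step. Compound 4 also shows a 1.3-fold higher number from compound 2 to compound 4 (0.12 log units; within the scatter) and a 1.9-fold lower number from compound 1 to compound 4 (0.28 log units; within the scatter), which places it level with two compounds that stand apart from each other. No evidence here explains these results. The compounds shown leave open how an open-chain amine such as diethylamino would compare, and what a carboxylic acid on the cyclohexyl ring would do.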